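The compounds below may be only part of what the source reports. "The series", "measured", "known", "first", "only" and "open" are said of these compounds alone.

Among the compounds with values here, in a functional assay on HeLa cells (Homo sapiens) for cytotoxicity, read by ELISA, with a stated time of 4 days (on this read-out lower numbers stand for stronger inhibition and higher numbers for weaker inhibition), three compounds have numbers so far: compound 1 `Clc1ccc(-c2cc(-c3ccco3)cc(-c3ccc(Cl)s3)n2)cc1` gives 17000 nM, compound 2 `Cc1ccccc1-c1cc(-c2ccoc2)cc(-c2ccc(Cl)s2)n1` gives 19000 nM, and compound 3 `Cc1cccc(-c2cc(-c3ccoc3)cc(-c3ccc(Cl)s3)n2)c1` gives 23600 nM. All three numbers lie within the scatter of one another, so compound 3 stands level with the other two. Compound 4 `Clc1ccc(-c2cc(-c3ccoc3)cc(-c3ccccc3Cl)n2)s1` has not yet been measured. It carries 2-chlorophenyl in place of 3-methylphenyl on an aromatic carbon, next to the ring nitrogen (2-chlorophenyl in place of 3-methylphenyl on an aromatic carbon). Within the data shown here, one measured step bears on this place: a 1.2-fold higher number from compound 2 to compound 3 (0.09 log units; within the scatter), with 3-methylphenyl in place of 2-methylphenyl, and it stays within the scatter. Among the measured compounds shown here, no measured step brings in 2-chlorophenyl, so the evidence is indirect. A change beyond the scatter in this assay is not expected, because a 1.2-fold higher number from compound 2 to compound 3 (0.09 log units; within the scatter) showed none at this place. The estimated step is a 1.3-fold lower number from compound 3 to compound 4 (0.12 log units; within the scatter). For compound 4 the expected value is 18000 nM, with an estimated range from 8000 nM to 35000 nM.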

Compound 4, half-maximal inhibitory concentration: 19000 nM
Estimate against measurement, compound 4: 1.1-fold (0.02 log units) below; low and high end bracket the measured number.
By their numbers in this assay, from the lowest: compounds 1, 2, 4 and 3 (each within the scatter of the next).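

In this assay the 2-chlorophenyl group at this place, next to the ring nitrogen, stands level with 3-methylphenyl (a 1.2-fold lower number from compound 3 to compound 4 (0.09 log units; within the scatter)). Within the data shown here, the new compound also gives the first direct exchange of chloro for methyl on this aromatic carbon (no change at the digits printed from compound 2 to compound 4 (within the scatter)), so 2-chlorophenyl and 2-methylphenyl cannot be told apart here. No measured evidence is at hand that would account for this.

Every compound shown carries a methyl or chloro group on the phenyl ring here, which leaves open whether an amine or a carboxylic acid on that ring, or a longer chain in its place, would give a step beyond the scatter. From the compounds shown here alone, compound 2, compound 3 and compound 4 all keep the 5-chlorothiophen-2-yl and furan-3-yl groups, so how the number responds to replacing either remains open.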